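A few compounds are considered here, and "the series" means these few. Any claim that something is new, unique, unknown or untested is made for them only; others in the source may bear on it.

Measured so far:
compound 1, `Cc1csc2cc([C@H](C)Nc3ncnc(N)c3C#N)c(-c3ccccc3)c(=O)n12`: 0%
compound 2, `Cc1csc2cc([C@H](C)Nc3ncnc(N)c3C#N)c(-c3cccc(CN(C)CCCN(C)Cc4ccc(Cl)cc4)c3)c(=O)n12`: 3.3%

In an ADME assay on the whole organism (lung, Rattus norvegicus) for metabolic stability, read by LC-MS, with a stated time of 24 h (a higher number here means that more of the compound is left, a lower number that less of the compound is left), compound 1 gives 0%. Compound 2 gives 3.3%. The two numbers lie within the scatter of each other, so neither compound stands apart from the other; both show next to nothing of the compound remaining.

Compound 3, `Cc1csc2cc([C@H](C)Nc3ncnc(N)c3C#N)c(Cc3cccc(CN(C)C)c3)c(=O)n12`, is not yet measured. It differs from compound 1 in one place: 3-((dimethylamino)methyl)benzyl in place of phenyl on an aromatic carbon. Within the data shown here, no step between measured compounds is available to size this kind of change. Among the measured compounds shown here, both measured values in this assay sit near the floor of the read-out, and the only measured pair shows no difference beyond the scatter, so the step is expected to be none beyond the scatter, a number 4 percentage points higher from compound 1 to compound 3 (within the scatter). Compound 3 is therefore estimated at 4%, with a range from 0% to 18%.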

Compound 3, percent of the compound remaining: 0%
Beside the measured number, compound 3's estimate is 4 percentage points above it, within the range that was stated.
By their numbers in this assay, from the lowest: compounds 1, 3 and 2 (each within the scatter of the next).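

In this assay, among these compounds, 3-((dimethylamino)methyl)benzyl in place of phenyl on this aromatic carbon gives no change at the digits printed from compound 1 to compound 3 (within the scatter) as the first step that can be read at this position. Among the compounds shown here, the step has little room to show a loss, since compound 3 stands at 0% at the bottom of the read-out, so it shows only that this change does not bring the number out of the scatter. Nothing at hand explains this result.

Open, from the compounds shown here alone, is whether any group on this aromatic carbon can bring the number clearly above that floor, for example a carboxylic acid, a primary amine or a small methyl. Also open, going by these compounds, is whether a change elsewhere on the shared core would give a number high enough for a step at this position to be sized.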